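From Nitro to Chloro: An Expected Small Step

The source may report more compounds than this note shows. Statements on the series, on what has been measured and on what is new or still open speak of the compounds shown alone.

In a functional assay on NCI-N87 cells (Homo sapiens) for antiproliferative activity, read by CCK-8 assay, with a stated time of 72 h (on this read-out lower numbers stand for stronger inhibition and higher numbers for weaker inhibition), compound 1 (`Cc1cc(Nc2cc(N3CCN(C)CC3)nc(Nc3ccc(S(N)(=O)=O)cc3)n2)n[nH]1`) gives 24000 nM, and compound 2 (`Cc1cc(Nc2cc(N3CCN(C)CC3)nc(Nc3ccc([N+](=O)[O-])cc3)n2)n[nH]1`) gives 3880 nM, the lower of the two numbers. Compound 3 (`Cc1cc(Nc2cc(N3CCN(C)CC3)nc(Nc3ccc(Cl)cc3)n2)n[nH]1`) carries chloro in place of nitro on an aromatic carbon. Going by the values given here, the only measured step bearing on this site is a 6.2-fold lower number from compound 1 to compound 2 (0.79 log units; beyond the scatter), a modest one that swaps sulfamoyl for nitro. It gives no measure for chloro, so no change beyond the scatter is expected in this assay. The expected step is a 1.3-fold lower number from compound 2 to compound 3 (0.11 log units; within the scatter). Compound 3 is estimated at 3000 nM, with an expected range of 1000 nM to 9000 nM.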

Compound 3, half-maximal inhibitory concentration: 7470 nM
Compound 3: middle estimate off by 2.5-fold (0.40 log units), on the low side; low and high end bracket the measured number.
By their numbers in this assay, from the lowest: compounds 2 and 3 (each within the scatter of the next); then compound 1.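

In this assay, chloro on this aromatic carbon gives a 1.9-fold higher number from compound 2 to compound 3 (0.28 log units; within the scatter), so the exchange of nitro for chloro, a single atom for three, does not move the number beyond the scatter. Sulfamoyl stands apart from both groups, with a 3.2-fold lower number from compound 1 to compound 3 (0.51 log units; beyond the scatter), a modest step in the same direction as the one from sulfamoyl to nitro. Nothing available explains these steps. The compounds shown leave open how an amine, a methoxy group or a carboxylic acid on this carbon would read, and whether fluoro would fall with chloro and nitro.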